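Taking the cyclopropyl group off compound 2

A few compounds are considered here, and "the series" means these few. Any claim that something is new, unique, unknown or untested is made for them only; others in the source may bear on it.

In a functional assay on HT-29 cells (Homo sapiens) for inhibition, read by sulforhodamine B assay, with a stated time of 72 h (on this read-out lower numbers stand for stronger inhibition and higher numbers for weaker inhibition), compound 1 `COc1ccc(C2C(Oc3ccccc3)C(=O)N2c2cc(OC)c(OC)c(OC)c2)cc1` gives 52 nM and compound 2 `COc1ccc(C2C(C3CC3)C(=O)N2c2cc(OC)c(OC)c(OC)c2)cc1` gives 107 nM. Among the compounds with values here, compound 2 therefore holds the higher, weaker number of the two measured so far. Compound 3 `COc1ccc(C2CC(=O)N2c2cc(OC)c(OC)c(OC)c2)cc1` is a plainer relative of compound 2: hydrogen in place of cyclopropyl on a saturated ring carbon. In short, hydrogen stands in place of cyclopropyl on a saturated ring carbon. Within the data shown here, one measured step bears on this carbon, a 2.1-fold higher number from compound 1 to compound 2 (0.31 log units; beyond the scatter), where cyclopropyl replaces phenoxy. That step is modest but beyond the scatter, so the group here does matter to the number. Among the measured compounds shown here, no measured compound lacks a group at this carbon, so the direction of the next step remains a judgement. A further modest rise seems the most likely outcome. The estimated change is a 1.9-fold higher number from compound 2 to compound 3 (0.27 log units; within the scatter) in this assay. For compound 3 the expected value is 200 nM, with an estimated range from 60 nM to 700 nM.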

Compound 3, half-maximal inhibitory concentration: 65 nM
Compound 3: the middle estimate sits 3.1-fold (0.49 log units) above what was measured; measured number inside the range.
By their numbers in this assay, from the lowest: compounds 1, 3 and 2 (each within the scatter of the next, the first and the last beyond it).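

In this assay, taking cyclopropyl off gives a 1.6-fold lower number from compound 2 to compound 3 (0.22 log units; within the scatter) and setting hydrogen against phenoxy gives a 1.3-fold higher number from compound 1 to compound 3 (0.10 log units; within the scatter), so neither group separates from plain hydrogen at this carbon. The carbon therefore needs no group for compound 3 to stay level with both compound 1 and compound 2, and the only gap beyond the scatter is the modest one between the phenoxy and cyclopropyl compounds. No supporting measurement here offers an explanation for these small differences.

The compounds shown leave open whether any group on this saturated ring carbon can move the number clearly away from that of compound 3. An amine, a carboxylic acid or a longer chain such as n-butyl in place of the hydrogen would test this, and the outcome in either direction cannot be read from these three compounds.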